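The source may hold more compounds than are shown below. What is called first, only, known or untested is meant among the compounds shown, and "the series" means these compounds.

Compound 3 `N=C(N)N/N=C/c1ccc(/C=C/C(=O)c2ccccc2Cl)cc1` gives 84.1% in a functional assay on the whole organism (Ear) for inhibition, with Mus musculus as the target, with a stated time of 30 min, at a dose of 100 mg/kg by the intraperitoneal route; on this read-out lower numbers stand for less inhibition and higher numbers for more inhibition at the one dose given (going by the name of the read-out). Of the three numbers shown, its number is the largest, yet the step of a number 6.4 percentage points higher from compound 1 to compound 3 (within the scatter) from compound 1 `Cc1ccc(C(=O)/C=C/c2ccc(/C=N/NC(=N)N)cc2)cc1`, which gives 77.7%, is within the scatter, while the step of a number 26.9 percentage points higher from compound 2 to compound 3 (beyond the scatter) from compound 2 `COc1ccc(C(=O)/C=C/c2ccc(/C=N/NC(=N)N)cc2)cc1`, which gives 57.2%, is beyond it. Compound 4 `N=C(N)N/N=C/c1ccc(/C=C/C(=O)c2ccccc2Br)cc1` differs from compound 3 only by bromo in place of chloro on an aromatic carbon. Going by the values given here, no measured step swaps one halogen for another: the steps of a number 20.5 percentage points lower from compound 1 to compound 2 (beyond the scatter) and a number 26.9 percentage points higher from compound 2 to compound 3 (beyond the scatter) exchange whole aryl groups, so they give no direct guide. With nothing pointing either way, compound 4 is expected to show a step of a number 0.1 percentage points lower from compound 3 to compound 4 (within the scatter), which is within the scatter. Compound 4 is therefore estimated at 84%, between 70% and 95%.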

Compound 4, a percentage reported as inhibition, in the whole organism at one dose (the size of the read-out at that dose, not a potency): 78.3%
The estimate for compound 4 lay 5.7 percentage points above the measured number; measured number inside the range.
By their numbers in this assay, from the lowest: compound 2; then compounds 1, 4 and 3 (each within the scatter of the next).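

Within this assay, the first direct exchange of one halogen for another, at this place ortho to a large group, gives a number 5.8 percentage points lower from compound 3 to compound 4 (within the scatter) and so does not separate chloro from bromo. Compared across whole aryl groups, the 2-bromophenyl compound shows a number 0.6 percentage points higher from compound 1 to compound 4 (within the scatter) against the 4-methylphenyl one, yet a number 21.1 percentage points higher from compound 2 to compound 4 (beyond the scatter) against the 4-methoxyphenyl one, leaving compound 2 as the only compound standing apart. Nothing measured here explains these numbers. On these data alone, what remains open is how a fluoro, an amine or a carboxylic acid at this same place would read out.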